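Urea Permeability Across Aryl Substituent Changes

The source may hold more compounds than are shown below. What is called first, only, known or untested is meant among the compounds shown, and "the series" means these compounds.

The measured compounds and their permeability numbers are:

Compound 1 `CCc1ccc(NC(=O)Nc2cc(C)nc3ccccc23)cc1`: 535 10^-6 cm/s
Compound 2 `COc1ccc(NC(=O)Nc2cc(C)nc3ccccc23)cc1Cl`: 336 10^-6 cm/s
Compound 3 `COc1ccc(NC(=O)Nc2cc(C)nc3ccccc23)cc1F`: 50 10^-6 cm/s

In an ADME assay for permeability, using PAMPA, at pH 7.4 (on this read-out lower numbers stand for lower permeability and higher numbers for higher permeability), compound 1 gives the highest of the three numbers, though compound 2 sits within the scatter of it, while compound 3 lies well beyond. Among the compounds with values here, the only step between neighbours is a 6.7-fold lower number from compound 2 to compound 3 (0.83 log units; beyond the scatter), a swap of one halogen for another at a different position on the ring.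

Compound 4 `Cc1cc(NC(=O)Nc2ccc(SC(F)(F)F)cc2)c2ccccc2n1` has not been measured. It differs from compound 1 as follows: (trifluoromethyl)sulfanyl in place of ethyl on an aromatic carbon. Within the data shown here, no measured step concerns this kind of change, so the step from compound 2 to compound 3 offers only a sense of how large a single-substituent swap on this ring can be. On that basis a move of at most modest size is expected, most likely downward, and the estimated step is a 1.4-fold lower number from compound 1 to compound 4 (0.15 log units; within the scatter). Compound 4 is therefore expected to give about 380 10^-6 cm/s in this assay, within a range from 120 10^-6 cm/s to 800 10^-6 cm/s.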

Compound 4, apparent permeability: 206 10^-6 cm/s
For compound 4 the middle estimate is 1.8-fold (0.27 log units) above the measured one; measured number inside the range.
By their numbers in this assay, from the lowest: compound 3; then compounds 4, 2 and 1 (each within the scatter of the next, the first and the last beyond it).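

In this assay, within the data shown here, replacing ethyl with (trifluoromethyl)sulfanyl on an aromatic carbon para to a large group gives a 2.6-fold lower number from compound 1 to compound 4 (0.41 log units; beyond the scatter) and so provides the first reading of a change at this place with the rest of the molecule held constant. The earlier step concerned only fluoro in place of chloro, so this result adds a different kind of swap, one in which the entering group has more heavy atoms and a hydrogen-bond acceptor, and the step still counts as modest. No measurement available here accounts for the size or direction of this step.

With a single pair at this place, no trend can be drawn from it. As far as these compounds go, it remains open how a longer chain, an amine or a carboxylic acid at the same carbon would compare with ethyl in this read-out.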